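Estimating compound 4 after a larger amine swap

A few compounds are considered here, and "the series" means these few. Any claim that something is new, unique, unknown or untested is made for them only; others in the source may bear on it.

Values in an ADME assay for permeability, using PAMPA, with a stated time of 4 h, at pH 5.5 (on this read-out higher numbers stand for higher permeability and lower numbers for lower permeability), so far
- compound 1 `NC(=O)NCCCCN(C[C@H]1Cc2ncccc2CN1)[C@H]1CCCc2cccnc21` gives 7 nm/s
- compound 2 `CN(C)CCCCN(C[C@H]1Cc2ncccc2CN1)[C@H]1CCCc2cccnc21` gives 2 nm/s
- compound 3 `CCN(CC)CCCCN(C[C@H]1Cc2ncccc2CN1)[C@H]1CCCc2cccnc21` gives 3 nm/s

Compound 3 sits low in this small set. The data show a 2.3-fold lower number from compound 1 to compound 3 (0.37 log units; beyond the scatter) and also a 1.5-fold higher number from compound 2 to compound 3 (0.18 log units; within the scatter) so compound 3 cannot be told apart from compound 2. Compound 4 `CN(CCCCN(C[C@H]1Cc2ncccc2CN1)[C@H]1CCCc2cccnc21)C1CCC(F)(F)CC1` follows with a group of 10 heavy atoms (7 carbon, 1 nitrogen, 2 fluorine; one six-membered non-aromatic ring of carbon only) in place of a group of 5 heavy atoms (4 carbon, 1 nitrogen; no ring), on a saturated chain carbon, four bonds along the chain from an amine nitrogen as its change. The closest guide is that swap between two amine groups, which stayed within the scatter. The larger steps, such as a 3.5-fold lower number from compound 1 to compound 2 (0.54 log units; beyond the scatter) here, involve ureido leaving. Within the data shown here, no measured compound carries a ring in this group, so the guide is thin. The estimate is a 1.3-fold higher number from compound 3 to compound 4 (0.12 log units; within the scatter) in size and no step beyond the scatter is expected in this assay for it. For compound 4 the estimated value is 4 nm/s with an expected range from 1.5 nm/s to 12 nm/s in this estimate.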

Compound 4, apparent permeability: 15 nm/s
Compound 4: the middle estimate sits 3.8-fold (0.57 log units) below what was measured; measured number above the stated range.
By their numbers in this assay, from the lowest: compounds 2 and 3 (each within the scatter of the next); then compound 1; then compound 4.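

In this assay there is a 5.0-fold higher number from compound 3 to compound 4 (0.70 log units; beyond the scatter) and a 7.5-fold higher number from compound 2 to compound 4 (0.88 log units; beyond the scatter) with the 4,4-difluorocyclohexyl group in the amine, so changing the amine group at this position can matter well beyond the scatter, which the two open-chain amines did not show. With a 2.1-fold higher number from compound 1 to compound 4 (0.33 log units; beyond the scatter) as well, an amine group here is not tied to numbers lower than the ureido compound's, and compound 4 goes against the pattern of compounds 2 and 3. No measured evidence offers an explanation for this step. From the compounds shown here alone, whether the ring or the fluorine atoms carry the step stays open, and a plain cyclohexyl group would separate the two.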